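The source may report more compounds than this note shows. Statements on the series, on what has been measured and on what is new or still open speak of the compounds shown alone.

Of the compounds shown here, two share a urea-linked core and have been tested in a functional assay on A549 cells (Homo sapiens) for inhibition, read by sulforhodamine B assay, with a stated time of 48 h; a lower number here means a stronger inhibitor, a higher number a weaker inhibitor. Compound 1 `O=C(Nc1ccc(C(=O)NO)cc1)Nc1ccc(Cl)c(C(F)(F)F)c1` carries the hydroxycarbamoyl group directly on the ring and gives 7200 nM in this assay. Compound 2 `O=C(CCCCCCC(=O)Nc1ccc(NC(=O)Nc2ccc(Cl)c(C(F)(F)F)c2)cc1)NO` instead places the hydroxycarbamoyl group at the end of a saturated chain, and in this assay compound 2 gives 9500 nM. Of the two numbers, compound 2 has the higher one, but its gap to compound 1 lies within the scatter, so the two cannot be told apart. Compound 3 `O=C(CCCCC(=O)Nc1ccc(NC(=O)Nc2ccc(Cl)c(C(F)(F)F)c2)cc1)NO` is not yet measured; it differs from compound 2 in one place: hydroxycarbamoyl in place of 2-(hydroxycarbamoyl)ethyl on a saturated chain carbon, four bonds along the chain from a carbonyl carbon. Among the measured compounds shown here, with no measured step on chain length to go by, the expected change is a small move toward a higher number, a 1.3-fold higher number from compound 2 to compound 3 (0.10 log units; within the scatter), likely within the scatter. The estimate for compound 3 in this assay is 12000 nM, with a range from 4000 nM to 40000 nM.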

Compound 3, half-maximal inhibitory concentration: > 10000 nM
Compound 3: only a limit was reported; the forecaster's own chance of this, stated with the estimate: 10%; the middle value is on the limit's open side.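

For compound 3 in this assay, > 10000 nM is a limit of the assay and not a number. Among the compounds shown here, this gives the first measured step on chain length at this position: hydroxycarbamoyl in place of 2-(hydroxycarbamoyl)ethyl on a saturated chain carbon gives an at least 1.0-fold higher number from compound 2 to compound 3 (0.02 log units; that floor lies within the scatter). That figure is only a floor, so the true size of the step stays unknown and the shorter chain cannot yet be told apart from the longer one: the limit of > 10000 nM in this assay, at which 1 of the 3 values shown sits.

For the compounds shown here, whether a chain longer than the one in compound 2 would move the number in either direction remains open. Also open, going by these compounds, is what a carboxylic acid at the chain end, in place of the hydroxycarbamoyl group, would do in this assay.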